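This account rests on a few compounds, and the source may have more. Where it says the series, first, only, none or still open, it means among the compounds named here.

Measured in an ADME assay on LLC-MK2 cells (Macaca mulatta) for cytotoxicity, read by MTT assay, with a stated time of 48 h; on this read-out lower numbers stand for higher toxicity in this test and higher numbers for lower toxicity in this test:

- compound 1 `C/C(=C\c1ccccc1)C(=O)/C=C/c1ccc(N(C)C)cc1`: 53000 nM
- compound 2 `COc1ccc(/C=C(\C)C(=O)/C=C/c2ccccc2)cc1`: 44000 nM
- compound 3 `COc1ccc(/C=C(\C)C(=O)/C=C/c2ccc([N+](=O)[O-])cc2)cc1`: 20100 nM

Compound 3 has the lowest number of the three, and its values to compound 1 and compound 2 both differ beyond the scatter. Compound 4 `COc1ccc(/C=C(\C)C(=O)/C=C/c2ccc(N(C)C)cc2)cc1` is next, with dimethylamino in place of nitro on an aromatic carbon, para to a large group: dimethylamino in place of nitro on an aromatic carbon.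

Within the data shown here, only one measured step bears directly on this change. Introducing nitro in place of hydrogen gave a 2.2-fold lower number from compound 2 to compound 3 (0.34 log units; beyond the scatter), a modest move in this assay. Compound 4 loses that nitro, so some return towards compound 2 at 44000 nM seems likely. Compound 1 also carries dimethylamino and gives 53000 nM, which lies within the scatter of the value of compound 2. Among the measured compounds shown here, no measured pair isolates dimethylamino against hydrogen on the shared core, so this support is indirect.

The expected change is a modest rise in the number, estimated as a 2.1-fold higher number from compound 3 to compound 4 (0.32 log units; beyond the scatter). For compound 4 the estimated value is 42000 nM, with an expected range of 20000 nM to 85000 nM.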

Compound 4, half-maximal cytotoxic concentration: 411000 nM
Beside the measured number, compound 4's estimate is 9.8-fold (0.99 log units) below it; measured number outside the range, above it.
By their numbers in this assay, from the lowest: compound 3; then compounds 2 and 1 (each within the scatter of the next); then compound 4.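

In this assay, replacing nitro with dimethylamino at this position, para to a large group, does more than remove the effect of nitro: a 20-fold higher number from compound 3 to compound 4 (1.31 log units; beyond the scatter), and the result also clears the compound with hydrogen at this place, with a 9.3-fold higher number from compound 2 to compound 4 (0.97 log units; beyond the scatter). The higher number therefore goes with the presence of dimethylamino, which points to lower toxicity in this test, and not merely with the loss of nitro. The methoxy on the other side of the series matters as well once dimethylamino is in place, with its addition giving a 7.8-fold higher number from compound 1 to compound 4 (0.89 log units; beyond the scatter), though nothing available accounts for either rise.

Going by these compounds, it remains open whether this rise is particular to dimethylamino or extends to other groups at this place, such as a primary amine, a longer dialkylamine or a carboxylic acid. Among these compounds, also open is whether methoxy in place of hydrogen gives a similar step when the position carries nitro or hydrogen rather than dimethylamino, since the only such step here has dimethylamino present.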